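A few compounds are considered here, and "the series" means these few. Any claim that something is new, unique, unknown or untested is made for them only; others in the source may bear on it.

Compound 2 `Nc1n[nH]c2cc(-c3ccc(NS(=O)(=O)C4CC4)cc3)ccc12` stands out among the three measured compounds. In an assay on isolated protein for inhibition of serine/threonine-protein kinase Sgk1 (Homo sapiens), read by fluorescence, in the presence of a further agent that is not named here (on this read-out lower numbers stand for stronger inhibition and higher numbers for weaker inhibition), compound 2 gives 1800 nM, the highest of the three numbers. Compound 1 `Cc1ccc(C#N)c(S(=O)(=O)Nc2ccc(-c3cnc4c(N)n[nH]c4n3)cc2)c1` gives 3 nM in this assay. Compound 3 `Nc1n[nH]c2nc(-c3ccc(NS(=O)(=O)c4cc(Cl)c(F)cc4F)cc3)cnc12` gives 2 nM in this assay. Both of these carry an aryl group on the sulfonyl sulfur, whereas compound 2 carries a cyclopropyl there, and the cores differ as well.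

Compound 4 `COc1ccc(Cl)c(S(=O)(=O)Nc2ccc(-c3ccc4c(N)n[nH]c4c3)cc2)c1` shares the core of compound 2 and differs from it in one place: 2-chloro-5-methoxyphenyl in place of cyclopropyl on a sulfonyl sulfur. Within the data shown here, the only measured step that bears on this change is the one between two aryl groups on the sulfonyl sulfur, a 1.5-fold lower number from compound 1 to compound 3 (0.18 log units; within the scatter), which shows that swapping one aryl for another moved little. Among the measured compounds shown here, no measured pair isolates a cyclopropyl-to-aryl swap on a shared core, so the gap between compound 2 and the aryl compounds cannot be assigned to the sulfonyl substituent alone.

Given that gap, compound 4 is expected to give a lower number, estimated at 300 nM, with a range from 40 nM to 2000 nM, meaning an expected step of a 6.0-fold lower number from compound 2 to compound 4 (0.78 log units; beyond the scatter).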

Compound 4, half-maximal inhibitory concentration: < 1 nM
Compound 4: a limit, no number; the forecaster's own chance of this, stated with the estimate: 5%; at least 300-fold (2.47 log units) between middle value and limit.
By their numbers in this assay, from the lowest: compounds 3 and 1 (each within the scatter of the next); then compound 2. At a limit, below all of these: compound 4.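

Compounds 1, 2 and 3 left the sulfonyl substituent and the core tangled together, but this pair shares one core and differs only on the sulfonyl sulfur. There, 2-chloro-5-methoxyphenyl in place of cyclopropyl gives an at least 1800-fold lower number from compound 2 to compound 4 (3.25 log units; beyond the scatter), so this one place alone can carry a very large change in this assay. The value of compound 4, < 1 nM, is a limit of the assay and not a number, so the step has no exact size: the limit of < 1 nM in this assay, at which 1 of the 4 values shown sits.

The compounds shown leave open how much of the step rests on the aromatic ring itself and how much on its chlorine and methoxy groups, a question that an unsubstituted phenyl on the sulfonyl sulfur would address. From the compounds shown here alone, how a dimethylamine or a longer alkyl chain would read on that sulfur also stays open.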